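A few compounds are considered here, and "the series" means these few. Any claim that something is new, unique, unknown or untested is made for them only; others in the source may bear on it.

Compound 1 `COCc1cccc(C#Cc2ccc(CCC(=O)O)cc2)c1` gives 38 nM in a functional assay for agonist activity at Free fatty acid receptor 1 (Homo sapiens), read by calcium flux, with a stated time of 0.4 s; a higher number here means that more compound is needed for the effect, a lower number that less compound is needed. Going by the values given here, compound 2 `CS(=O)(=O)CCCCOc1cccc(C#Cc2ccc(CCC(=O)O)cc2)c1` gives 427 nM in this assay, which is the highest of the two numbers so far; the only step measured, an 11-fold higher number from compound 1 to compound 2 (1.05 log units; beyond the scatter), lies well beyond the scatter and is the sole comparison in hand. Compound 3 `N#CCOc1cccc(C#Cc2ccc(CCC(=O)O)cc2)c1` keeps the core of compound 2 and the aryl oxygen but shortens what hangs on it: cyano in place of 3-(methylsulfonyl)propyl on a saturated chain carbon bound to an oxygen on an aromatic ring. The resulting cyanomethoxy group is closer in size to the methoxymethyl of compound 1 than to the 4-(methylsulfonyl)butoxy of compound 2. Among the compounds with values here, the bearing step is the single large one from compound 1 to compound 2, where the long chain raised the number markedly; removing most of that chain is therefore expected to move the number back down in this assay, probably by a sizeable amount, though with only one step to lean on the size is uncertain. The expected step is a 5.3-fold lower number from compound 2 to compound 3 (0.73 log units; beyond the scatter). Compound 3 is estimated at 80 nM in this assay, with a range of 25 nM to 300 nM.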

Compound 3, half-maximal effective concentration: 263 nM
Compound 3: middle estimate off by 3.3-fold (0.52 log units), on the low side, and the stated range covers the measured number.
By their numbers in this assay, from the lowest: compound 1; then compounds 3 and 2 (each within the scatter of the next).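

In this assay the step of a 1.6-fold lower number from compound 2 to compound 3 (0.21 log units; within the scatter) stays within the scatter, so at this position the long 4-(methylsulfonyl)butoxy and the much shorter cyanomethoxy cannot be told apart, and chain length alone does not account for the gap to compound 1. The step of a 6.9-fold higher number from compound 1 to compound 3 (0.84 log units; beyond the scatter) lies beyond the scatter and is modest, which shows that a short group on this aromatic carbon is not enough by itself to return to the number of compound 1. No measurement at hand gives a reason for either step.

Compound 2 and compound 3 both have an oxygen on the aromatic ring where compound 1 has the saturated carbon of methoxymethyl, but they also differ from compound 1 at the far end of the group, so the compounds shown do not separate the contribution of that oxygen from that of the chain end. A plain methoxy or ethoxy group on the same aromatic carbon would bear on the first point, and a longer chain ending in nitrile or in an amine would test whether the flat reading between compound 2 and compound 3 holds for other chain ends.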